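Longer hydroxycarbamoyl chain on the core of compound 1

The compounds below may be only part of what the source reports. "The series", "measured", "known", "first", "only" and "open" are said of these compounds alone.

Compound 1 `Nc1ncnc2c1c(-c1cnc3[nH]ccc3c1)nn2CC(=O)NO` gives > 150000 nM in a functional assay on HCT-116 cells (Homo sapiens) for inhibition, read by MTT assay, with a stated time of 72 h (on this read-out higher numbers stand for weaker inhibition and lower numbers for stronger inhibition), as its reading, which is a limit and not a number. Among the compounds with values here, compound 2 `Nc1nc2cc(-c3nn(CCCC(=O)NO)c4ncnc(N)c34)ccc2o1` gives 19600 nM in this assay as the only true number so far. Compound 3 `Nc1ncnc2c1c(-c1cnc3[nH]ccc3c1)nn2CCCCC(=O)NO` carries 3-(hydroxycarbamoyl)propyl in place of hydroxycarbamoyl on a saturated chain carbon bound to an aromatic nitrogen and awaits measurement. No measured step sizes this change. A large move toward stronger inhibition in this assay is expected, with an at least 7.5-fold lower number from compound 1 to compound 3 (0.87 log units; beyond the scatter) as the estimated step. This expectation leans on compound 2 at 19600 nM as the sole numerical anchor. For compound 3 the estimated value is 20000 nM with an expected range of 3000 nM to 120000 nM for now.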

Compound 3, half-maximal inhibitory concentration: > 150000 nM
Compound 3: no number, only a limit; the forecaster's own chance of this, stated with the estimate: 20%; at least 7.5-fold (0.87 log units) between middle value and limit.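

In this assay no step can be read from compound 1 to compound 3, as both readings are limits and not numbers: the limit of > 150000 nM in this assay, at which 2 of the 3 values shown sit.

As far as these compounds go, whether 3-(hydroxycarbamoyl)propyl in place of hydroxycarbamoyl changes inhibition on the core of compound 1 stays open.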